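This account rests on a few compounds, and the source may have more. Where it says the series, first, only, none or still open, it means among the compounds named here.

Of the compounds shown here, three have been measured in a physicochemical assay for solubility, read by nephelometry, in phosphate buffer, at pH 7.4 (a higher number here means a more soluble compound, a lower number a less soluble compound), and compound 2 `Cc1cc2ccccc2n1CCNC(=O)/C=C/c1ccc(OCCO)c(OCCO)c1` holds the second highest of the three numbers, giving 153000 nM. The nearest number belongs to compound 1 `Cc1cc2ccccc2n1CCNC(=O)/C=C/c1ccc(OCCCN(C)C)cc1`, which in this assay gives 306000 nM, a gap that falls within the scatter of this kind of measurement. The furthest belongs to compound 3 `COc1cc(/C=C/C(=O)NCCn2c(C)c(CN3CCCCC3)c3ccccc32)cc(OC)c1OC`, which in this assay gives 75000 nM, a lower number that lies beyond the scatter.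

The unmeasured compound 4 `O=C(/C=C/c1ccc(OCCO)c(OCCO)c1)NCCn1c(C(F)(F)F)cc2ccccc21` differs from compound 2 in one place: trifluoromethyl in place of methyl on an aromatic carbon. Going by the values given here, no pair among the measured compounds shows this exchange of trifluoromethyl for methyl, so there is no measured step to lean on. The expectation for the step from compound 2 to compound 4 in this assay is a modest fall, somewhat beyond the scatter, of about a 2.0-fold lower number from compound 2 to compound 4 (0.31 log units; beyond the scatter). Compound 4 is therefore estimated at 75000 nM in this assay, with a likely range from 30000 nM to 190000 nM.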

Compound 4, solubility: 67000 nM
Estimate against measurement, compound 4: 1.1-fold (0.05 log units) above; the measured number falls inside the stated range.
By their numbers in this assay, from the lowest: compounds 4 and 3 (each within the scatter of the next); then compounds 2 and 1 (each within the scatter of the next).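

In this assay, going by these compounds alone, putting trifluoromethyl in place of methyl on an aromatic carbon next to the ring nitrogen gives a 2.3-fold lower number from compound 2 to compound 4 (0.36 log units; beyond the scatter) and so provides the first measured step here between two compounds that differ in one place. This position therefore responds measurably to the exchange, although the step is modest. Neither group carries a hydrogen-bond donor, a hydrogen-bond acceptor or a net charge, and nothing available explains the lower number.

Only one exchange at this position is shown, so it remains open how other groups there, such as a chlorine atom, a nitrile or an amine, would compare with methyl. From the compounds shown here alone, it is also open whether trifluoromethyl would give a similar step in a compound carrying the other parts of compound 1.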